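This account rests on a few compounds, and the source may have more. Where it says the series, first, only, none or still open, it means among the compounds named here.

Compound 3 `CC(C)C[C@H](N)c1cc(C(F)(F)F)ccc1N1CCN(C(=O)CCNC2CCCCC2)CC1` gives 4800 nM in an assay on HEK293 cells for displacement of a labelled ligand from Melanocortin receptor 4 (Homo sapiens) (on this read-out higher numbers stand for weaker inhibition and lower numbers for stronger inhibition), the highest number of the three measured and therefore the weakest binder. Compound 1 `COc1cc(CC(C)C(=O)N2CCN(c3ccc(C(F)(F)F)cc3[C@@H](N)CC(C)C)CC2)ccc1Cl` gives 230 nM, and compound 2 `CC(C)C[C@H](N)c1cc(C(F)(F)F)ccc1N1CCN(C(=O)CC(C)C(=O)c2ccc(Cl)cc2)CC1` gives 1100 nM. All three differ only in the chain beyond the carbonyl: a 21-fold higher number from compound 1 to compound 3 (1.32 log units; beyond the scatter) and a 4.4-fold higher number from compound 2 to compound 3 (0.64 log units; beyond the scatter), each a loss as the cyclohexylamino end replaced a ring-bearing group. Compound 4 `CC(C)C[C@H](N)c1cc(C(F)(F)F)ccc1N1CCN(C(=O)CCC(=O)N(C)C)CC1` carries dimethylcarbamoyl in place of cyclohexylamino on a saturated chain carbon, two bonds along the chain from a carbonyl carbon. Among the compounds with values here, no measured step covers this exact change, so the expectation rests on the trend alone. Because a 4.4-fold higher number from compound 2 to compound 3 (0.64 log units; beyond the scatter) already ran toward weaker binding, and compound 4 keeps no ring at all, a further modest loss is expected, a 1.5-fold higher number from compound 3 to compound 4 (0.16 log units; within the scatter). For compound 4 a value of 7000 nM is estimated, within 2500 nM to 20000 nM.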

Compound 4, inhibition constant: > 10000 nM
Compound 4: a limit, no number; the forecaster's own chance of this, stated with the estimate: 15%; middle value at least 1.4-fold (0.15 log units) from the limit.
By their numbers in this assay, from the lowest: compound 1; then compound 2; then compound 3. At a limit, above all of these: compound 4.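

Compound 4 is a limit and not a number: the limit of > 10000 nM in this assay, at which 1 of the 4 values shown sits. Putting dimethylcarbamoyl in place of cyclohexylamino on this saturated chain carbon gives an at least 2.0-fold higher number from compound 3 to compound 4 (0.31 log units; beyond the scatter), so this is the first chain end shown without a ring, and binding falls further even from the weakest earlier compound. The gaps to the compounds with aromatic rings widen to an at least 9.0-fold higher number from compound 2 to compound 4 (0.95 log units; beyond the scatter) and an at least 43-fold higher number from compound 1 to compound 4 (1.63 log units; beyond the scatter).

This change removes the ring and the amino nitrogen together, so the compounds shown cannot tell which of the two counts. A dimethylamino or cyclohexylcarbamoyl group at this place would separate them.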